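The source may hold more compounds than are shown below. What is called first, only, known or untested is meant among the compounds shown, and "the series" means these compounds.

Working notes on the series. Compound 1 `O=C(Nc1ccccc1F)c1cccc2[nH]c(-c3ccccn3)nc12` gives 54.7 uM in an ADME assay on Vero cells (Chlorocebus sabaeus) for cytotoxicity; on this read-out higher numbers stand for lower toxicity in this test and lower numbers for higher toxicity in this test. Compound 2 `Cc1csc(NC(=O)c2cccc3[nH]c(-c4ccccn4)nc23)n1` carries 4-methyl-1,3-thiazol-2-yl in place of 2-fluorophenyl on an amide-type nitrogen relative to compound 1; in this assay compound 2 gives 17.7 uM, and the step is a 3.1-fold lower number from compound 1 to compound 2 (0.49 log units; beyond the scatter). Compound 3 `O=C(Nc1ccccc1F)c1cccc2[nH]c(-c3ccncc3)nc12` gives 111 uM in this assay, the highest of the three measured numbers; its step from compound 1 is a 2.0-fold higher number from compound 1 to compound 3 (0.31 log units; beyond the scatter).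

Compound 4 `Cc1csc(NC(=O)c2cccc3[nH]c(-c4ccncc4)nc23)n1` is not yet measured. It differs from compound 3 by 4-methyl-1,3-thiazol-2-yl in place of 2-fluorophenyl on an amide-type nitrogen, the same change as between compound 1 and compound 2, at a place described in identical words; the cores of compound 3 and compound 1 differ by pyridin-4-yl in place of pyridin-2-yl on an aromatic carbon.

Within the data shown here, the step from compound 3 to compound 4 in this assay is expected to be a 3.1-fold lower number from compound 3 to compound 4 (0.49 log units; beyond the scatter), set beside the earlier one because a 3.1-fold lower number from compound 1 to compound 2 (0.49 log units; beyond the scatter) is the only measured instance of this change. Compound 4 is therefore estimated at 36 uM in this assay, with an expected range from 18 uM to 72 uM.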

Compound 4, half-maximal toxic concentration: 111 uM
Estimate against measurement, compound 4: 3.1-fold (0.49 log units) below; measured number outside the range, above it.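

On the core of compound 3, 4-methyl-1,3-thiazol-2-yl in place of 2-fluorophenyl gives no change at the digits printed from compound 3 to compound 4 (within the scatter), so in this assay the step seen on the core of compound 1 does not carry over: the same change on two cores in this assay, a 3.1-fold lower number (0.49 log units; beyond the scatter) from compound 1 to compound 2 and no change at the digits printed (within the scatter) from compound 3 to compound 4, 3.1-fold (0.49 log units) apart, beyond the scatter of two such steps. Pyridin-4-yl in place of pyridin-2-yl gives a higher number on both pairs, but the size depends on the amide group, with a 6.3-fold higher number from compound 2 to compound 4 (0.80 log units; beyond the scatter): the same change on two cores in this assay, a 2.0-fold higher number (0.31 log units; beyond the scatter) from compound 1 to compound 3 and a 6.3-fold higher number (0.80 log units; beyond the scatter) from compound 2 to compound 4, 3.1-fold (0.49 log units) apart, beyond the scatter of two such steps. These four compounds show that the two changes do not add independently in this assay; they do not show why, or whether the same holds beyond this one pair of cores.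

Still open, as far as these compounds go, is whether other groups on the amide-type nitrogen, such as cyclohexyl or 2-chlorophenyl, follow the thiazole or the fluorophenyl pattern. Also open, from the compounds shown here alone, is how pyridin-3-yl on the aromatic carbon would behave with either amide group.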